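Swapping the Ring on the Amide Nitrogen

A few compounds are considered here, and "the series" means these few. Any claim that something is new, unique, unknown or untested is made for them only; others in the source may bear on it.

Compound 3 `CC(=O)N1CCC(NC(=O)c2ccncc2Nc2cc(-c3ccc4ccn(C)c4c3)c3nccnc3c2)CC1` gives the lowest number among the three measured compounds in an assay for inhibition of 6-phosphofructo-2-kinase/fructose-2,6-bisphosphatase 3 (Homo sapiens), read by ADP-Glo, with a stated time of 2 h (a higher number here means a weaker inhibitor, a lower number a stronger inhibitor), with 18 nM. Its nearest neighbour is compound 2 `Cn1cc(NC(=O)c2ccncc2Nc2cc(-c3ccc4ccn(C)c4c3)c3nccnc3c2)cn1`, which gives 33 nM, and the step of a 1.8-fold lower number from compound 2 to compound 3 (0.26 log units; within the scatter) lies within the scatter. The furthest is compound 1 `CNC(=O)c1ccncc1Nc1cc(-c2ccc3ccn(C)c3c2)c2nccnc2c1`, which gives 83 nM, and the step of a 4.6-fold lower number from compound 1 to compound 3 (0.66 log units; beyond the scatter) is modest but beyond the scatter; the step of a 2.5-fold lower number from compound 1 to compound 2 (0.40 log units; beyond the scatter) is modest as well. Compound 4 `CN1CCC(NC(=O)c2ccncc2Nc2cc(-c3ccc4ccn(C)c4c3)c3nccnc3c2)CC1=O` has not yet been measured. It differs from compound 3 in one place: 1-methyl-2-oxopiperidin-4-yl in place of 1-acetylpiperidin-4-yl on an amide-type nitrogen. Among the compounds with values here, the steps that bear on this change are those in which the group on the amide-type nitrogen was varied: the two replacements of methyl by a ring each lowered the number modestly, while the exchange of one ring for another stayed within the scatter. For compound 4 the step of a 1.4-fold higher number from compound 3 to compound 4 (0.14 log units; within the scatter) is therefore expected to be small, most likely within the scatter, with no clear direction. The value for compound 4 in this assay is estimated at 25 nM, within a range of 10 nM to 60 nM.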

Compound 4, half-maximal inhibitory concentration: 41 nM
Compound 4: middle estimate off by 1.6-fold (0.21 log units), on the low side; the range from low to high includes it.
By their numbers in this assay, from the lowest: compounds 3, 2 and 4 (each within the scatter of the next, the first and the last beyond it); then compound 1.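

In this assay, moving from 1-acetylpiperidin-4-yl to 1-methyl-2-oxopiperidin-4-yl gives a 2.3-fold higher number from compound 3 to compound 4 (0.36 log units; beyond the scatter), which shows that exchanging one six-membered non-aromatic ring for another on the amide-type nitrogen can matter beyond the scatter, even though both groups have the same counted hydrogen-bond donors and acceptors. The 1-methyl-2-oxopiperidin-4-yl group is not separated from 1-methyl-1H-pyrazol-4-yl, with a 1.2-fold higher number from compound 2 to compound 4 (0.09 log units; within the scatter), while replacing methyl with it still gives a 2.0-fold lower number from compound 1 to compound 4 (0.31 log units; beyond the scatter), so all three ring groups shown give lower numbers than methyl. Nothing available accounts for the difference between the two piperidine groups.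

The compounds shown leave open how a free piperidin-4-yl amine, a carboxylic acid or a longer chain such as 2-methoxyethyl on this nitrogen would read in this assay. They also leave open whether the step from compound 3 to compound 4 would carry over to another core.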